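Dropping a Chloro Group in Two Related Pairs

The source may report more compounds than this note shows. Statements on the series, on what has been measured and on what is new or still open speak of the compounds shown alone.

Four compounds are compared in a physicochemical assay for lipophilicity, measured as octanol-water partition; a higher number here means a more lipophilic compound, a lower number a more polar compound. Compound 1 has the structure `OCC(O)COc1ccc(Cl)cc1Cl` and gives 1.99 in this assay. Compound 2, with the structure `OCC(O)COc1ccccc1Cl`, gives 1.29. The change between the two is hydrogen in place of chloro on an aromatic carbon, and the step it made is a number 0.70 log units lower from compound 1 to compound 2 (beyond the scatter).

Compound 3, with the structure `Cc1cc(Cl)ccc1OCC(C)O`, gives 2.84 in this assay, the highest of the three measured values, standing beyond the scatter from both compound 1 and compound 2. The difference between the core of compound 3 and the core of compound 1 is not broken down here.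

Compound 4, with the structure `Cc1ccccc1OCC(C)O`, has not yet been measured. It differs from compound 3 by hydrogen in place of chloro on an aromatic carbon. Going by the values given here, this is the same kind of change as the one between compound 1 and compound 2, but the surroundings differ: in compound 1 the departing chloro sits meta to a chloro group and para to a group of 6 heavy atoms, whereas in compound 3 it sits meta to a methyl group and para to a group of 5 heavy atoms.

The expectation for compound 4 rests on the measured step of a number 0.70 log units lower from compound 1 to compound 2 (beyond the scatter), which shows how much this kind of change lowered the value. A similar step is estimated here: a number 0.70 log units lower from compound 3 to compound 4 (beyond the scatter). Compound 4 is therefore expected to give about 2.14, with the estimate ranging from 1.8 to 2.5.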

Compound 4, partition coefficient: 2.14
For compound 4 middle estimate and measured number coincide at the digits printed; low and high end bracket the measured number.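

In this assay the swap of chloro for hydrogen on an aromatic carbon gave a number 0.70 log units lower from compound 3 to compound 4 (beyond the scatter) and, on the core of compound 1, gave a number 0.70 log units lower from compound 1 to compound 2 (beyond the scatter); the two steps match at the digits printed, so in these two pairs the change carried from one core to the other with its size intact. This agreement holds even though the surroundings differ, since on the core of compound 3 the chloro sits meta to a methyl group and para to a group of 5 heavy atoms, but two pairs are a small sample and set no rule for any other core in this series. No measurement is available that explains why the two steps agree.

The compounds shown leave open whether a step of this size would appear on a core carrying an amine or a carboxylic acid, or a longer chain in place of the present one. They also leave open what happens when a group other than hydrogen, such as fluoro or methoxy, takes the place of the chloro on either core.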